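The source may hold more compounds than are shown below. What is called first, only, known or untested is meant among the compounds shown, and "the series" means these compounds.

Measured compounds:
Compound 1 `CN1CCN(Cc2ccc(NC(=O)Nc3ccc4ncnc(Nc5ccc(F)c(Cl)c5)c4c3)cc2)CC1` gives 3480 nM in a functional assay on A549 cells (Homo sapiens) for antiproliferative activity, read by MTT assay, with a stated time of 72 h; on this read-out lower numbers stand for stronger inhibition and higher numbers for weaker inhibition.
Compound 2 `CN1CCN(Cc2ccc(NC(=O)Nc3ccc4ncnc(Nc5cccc(C(F)(F)F)c5)c4c3)cc2)CC1` gives 1650 nM in this assay.

Of the two numbers, compound 2 has the lower one; its nearest neighbour is compound 1, and the step of a 2.1-fold lower number from compound 1 to compound 2 (0.32 log units; beyond the scatter) separates them. That step is the only one known here, and it concerns the same place in which compound 3 `C[C@@H](Nc1ncnc2ccc(NC(=O)Nc3ccc(CN4CCN(C)CC4)cc3)cc12)c1ccccc1` differs from compound 2: 1-phenylethyl in place of 3-(trifluoromethyl)phenyl on a nitrogen on an aromatic ring. The known step shows that exchanging the group on this nitrogen moves the number only modestly, yet the exchange that leads to compound 3 is a different one, so its direction cannot be read from compound 1 and compound 2 alone. A step of roughly the same size, in either direction, is the most that can reasonably be expected, with the number of compound 2 as the anchor and a wide margin on both sides. For compound 3 the estimate is therefore 2500 nM in this assay, between 800 nM and 8000 nM. This amounts to an expected step of a 1.5-fold higher number from compound 2 to compound 3 (0.18 log units; within the scatter).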

Compound 3, half-maximal inhibitory concentration: > 10000 nM
Compound 3 ended at the assay's limit; the forecaster's own chance of this, stated with the estimate: 5%; middle value at least 4.0-fold (0.60 log units) away from the limit.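

Within the data shown here, compound 1 and compound 2 showed only that one substituted phenyl group on this nitrogen can replace another with a modest change in this assay. Compound 3 shows that this tolerance does not extend to every aromatic group here: 1-phenylethyl in place of 3-(trifluoromethyl)phenyl gives an at least 6.0-fold higher number from compound 2 to compound 3 (0.78 log units; beyond the scatter), and 1-phenylethyl in place of 3-chloro-4-fluorophenyl gives an at least 2.8-fold higher number from compound 1 to compound 3 (0.45 log units; beyond the scatter). Neither step has a known full size, since the reading for compound 3 is a limit of the assay and not a number: the limit of > 10000 nM in this assay, at which 1 of the 3 values shown sits.

This one exchange alters several things at once: the halogens go, the ring no longer sits directly on the nitrogen, and a defined stereocentre enters, and the three compounds cannot separate these changes. A plain phenyl or a benzyl group on this nitrogen would help to tell them apart, as would the mirror-image form of 1-phenylethyl, while the cause of the loss remains open.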